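A few compounds are considered here, and "the series" means these few. Any claim that something is new, unique, unknown or untested is made for them only; others in the source may bear on it.

Working notes on the series. All compounds share one core carrying a substituted phenyl on an oxygen on an aromatic ring, and all are read in a functional assay on Huh-7 cells (Homo sapiens) for inhibition, read by MTT assay, with a stated time of 48 h; a lower number here means a stronger inhibitor, a higher number a weaker inhibitor. Within the data shown here, compound 3 `Cc1nnsc1CO/N=C/c1c(C)nn(C)c1Oc1ccc(Br)cc1` gives 11800 nM, the only actual number among the three measured compounds. Compound 1 `Cc1nnsc1CO/N=C/c1c(C)nn(C)c1Oc1cccc(F)c1` returns only a limit of the assay, > 50000 nM. Compound 2 `Cc1nnsc1CO/N=C/c1c(C)nn(C)c1Oc1ccc(F)cc1` likewise returns only a limit, > 50000 nM. The step that the two limits leave unreadable from compound 1 to compound 2 is therefore unreadable. The steps of an at least 4.2-fold lower number from compound 1 to compound 3 (0.62 log units; beyond the scatter) and an at least 4.2-fold lower number from compound 2 to compound 3 (0.62 log units; beyond the scatter) point the same way and are bounded by the limit of > 50000 nM in this assay, at which 2 of the 3 values shown sit. Compound 4 `Cc1cccc(Oc2c(/C=N/OCc3snnc3C)c(C)nn2C)c1` is not yet measured; its change from compound 3 is 3-methylphenyl in place of 4-bromophenyl on an oxygen on an aromatic ring. Among the measured compounds shown here, no measured step swaps bromo for methyl, so the size of this step is uncertain; the two steps into compound 3 show only that bromo outperformed fluoro, which leaves the direction of a loss plausible once bromo leaves. The number is expected to rise in this assay, the expected step being a 2.5-fold higher number from compound 3 to compound 4 (0.41 log units; beyond the scatter). Compound 4 is expected at 30000 nM, within 10000 nM to 90000 nM.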

Compound 4, half-maximal inhibitory concentration: > 50000 nM
Compound 4: no number, only a limit; the forecaster's own chance of this, stated with the estimate: 40%; middle value at least 1.6-fold (0.22 log units) away from the limit.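

Compound 4 gives > 50000 nM in this assay and this is a limit of the assay, not a number. Among these compounds, the change to 3-methylphenyl gives an at least 4.2-fold higher number from compound 3 to compound 4 (0.62 log units; beyond the scatter) and so extends the loss on leaving 4-bromophenyl beyond the two fluorophenyl compounds, leaving 4-bromophenyl as the only group on this oxygen with a measured number, although the substituent and its ring position change together in this step. The steps from compound 1 and from compound 2 to compound 4 cannot be read, since each joins two limits: the limit of > 50000 nM in this assay, at which 3 of the 4 values shown sit.

The compounds shown leave open whether the bromo group or its ring position carries the difference, which 3-bromophenyl and 4-methylphenyl would separate. As far as these compounds go, how far potency goes beyond compound 3 also stays open, for example with 4-chlorophenyl, 4-iodophenyl or a phenyl bearing an amine.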